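The source may report more compounds than this note shows. Statements on the series, on what has been measured and on what is new or still open speak of the compounds shown alone.

Measured so far:
Compound 1 `CC1(C)O[C@H]2O[C@H](Cn3cc(CN4C(=O)/C(=N\Nc5ccc(Br)cc5)c5ccccc54)nn3)[C@H](O)[C@H]2O1`: 72900 nM
Compound 2 `CC1(C)O[C@H]2O[C@H](Cn3cc(CN4C(=O)/C(=N\Nc5ccc(C#N)cc5)c5ccccc54)nn3)[C@H](O)[C@H]2O1`: 105000 nM

Of the compounds shown here, two have been tested in an ADME assay on Vero cells (Chlorocebus sabaeus) for cytotoxicity, read by fluorescence and resazurin assay, with a stated time of 3 days; a lower number here means that less compound is tolerated, a higher number that more compound is tolerated. Within the data shown here, compound 1 gives 72900 nM, the lowest of the two numbers, and its nearest neighbour is compound 2 with 105000 nM; the only step between them, a 1.4-fold higher number from compound 1 to compound 2 (0.16 log units; within the scatter), is within the scatter, so the two compounds tolerate about the same amount of compound in this assay.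

The next compound, compound 3 `O=C1/C(=N\Nc2ccc(Br)cc2)c2ccccc2N1Cc1cn(O[C@@H]2O[C@H](CO)[C@H](O)[C@H](O)[C@H]2O)nn1`, keeps the bromo-bearing part of compound 1 and changes the other end: a group of 12 heavy atoms (6 carbon, 6 oxygen; one six-membered non-aromatic ring with 1 hetero atom) in place of a group of 12 heavy atoms (8 carbon, 4 oxygen; one five-membered non-aromatic ring with 1 hetero atom, one five-membered non-aromatic ring with 2 hetero atoms), on an aromatic nitrogen.

Among the measured compounds shown here, no measured step bears directly on this change. For the measured compounds named here, the one step available, from compound 1 to compound 2, swaps cyano for bromo on an aromatic carbon and leaves the sugar-like part untouched; it was within the scatter. There is therefore no basis in these numbers for expecting a shift in this assay in either direction beyond the scatter.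

Compound 3 is accordingly estimated to give 80000 nM, with a likely range from 30000 nM to 200000 nM. That estimate means an expected step of a 1.1-fold higher number from compound 1 to compound 3 (0.04 log units; within the scatter), within the scatter.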

Compound 3, half-maximal cytotoxic concentration: 91500 nM
Estimate against measurement, compound 3: 1.1-fold (0.06 log units) below; the range from low to high includes it.
By their numbers in this assay, from the lowest: compounds 1, 3 and 2 (each within the scatter of the next).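

In this assay, among these compounds, the group on the aromatic nitrogen of the five-membered aromatic ring with 3 nitrogen can be read for the first time, and exchanging it gives a 1.3-fold higher number from compound 1 to compound 3 (0.10 log units; within the scatter). The group that enters, (3,4,5-trihydroxy-6-(hydroxymethyl)oxan-2-yl)oxy, has the same count of 12 heavy atoms as the group that leaves, but it differs in its ring and carries 4 hydrogen-bond donors and 6 hydrogen-bond acceptors in place of 1 and 4, so a clear change in these counts at this position comes with a step that stays within the scatter, just as the exchange of bromo for cyano at the other end of the molecule did. Nothing available explains why the two groups read alike here.

On these data alone, it remains open whether a much smaller or differently built group on this nitrogen, such as an amine, a carboxylic acid or a longer chain, would also stay within the scatter. As far as these compounds go, it is equally open whether the cyano group of compound 2, paired with the group that compound 3 carries, would read the same way.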